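Swapping the sulfonamide cyclopentyl for a hydroxypropyl chain

The source may report more compounds than this note shows. Statements on the series, on what has been measured and on what is new or still open speak of the compounds shown alone.

The series centres on compound 1, `CC[C@@H]1C(=O)N(C)c2cnc(Nc3ccc(S(=O)(=O)NC4CCCC4)cc3)nc2N1C1CCCC1`, which in a functional assay on HeLa cells (Homo sapiens) for antiproliferative activity, read by CCK-8 assay, with a stated time of 72 h (on this read-out lower numbers stand for stronger inhibition of growth and higher numbers for weaker inhibition of growth), gives 609 nM, the lowest of the two numbers recorded here. Compound 2, `CCCCNS(=O)(=O)c1ccc(Nc2ncc3c(n2)N(c2ccn(C)n2)C(CC)C(=O)N3C)cc1`, differs from it in more than one place and in this assay gives 4320 nM, a number well beyond the scatter above that of compound 1. The new compound 3, `CC[C@@H]1C(=O)N(C)c2cnc(Nc3ccc(S(=O)(=O)NCCCO)cc3)nc2N1C1CCCC1`, is the single-point variant of compound 1 described by 3-hydroxypropyl in place of cyclopentyl on a sulfonamide nitrogen. For the measured compounds named here, no measured pair in the set isolates this kind of change, so the direction can only be guessed from the standing of compound 1. The expectation is that compound 3 will come out somewhat weaker, with the step of a 1.8-fold higher number from compound 1 to compound 3 (0.26 log units; within the scatter) judged to lie near the edge of the scatter rather than far beyond it. On that basis compound 3 is estimated at 1100 nM in this assay, within a range from 350 nM to 3500 nM.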

Compound 3, concentration for 50% growth inhibition: 357 nM
Compound 3: middle estimate off by 3.1-fold (0.49 log units), on the high side; measured number inside the range.
By their numbers in this assay, from the lowest: compounds 3 and 1 (each within the scatter of the next); then compound 2.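

In this assay, for the compounds shown here, the change from cyclopentyl to 3-hydroxypropyl on the sulfonamide nitrogen gives a 1.7-fold lower number from compound 1 to compound 3 (0.23 log units; within the scatter) and is the first comparison that isolates this position. The two compounds cannot be told apart on this read-out. At this position, then, the five-membered ring of carbon only can give way to an open chain carrying a hydrogen-bond donor and acceptor with no change beyond the scatter. Nothing measured here offers an explanation for this result.

On these data alone, it remains open whether a longer chain, a 3-aminopropyl group or a carboxylic acid on this sulfonamide nitrogen would also stay within the scatter of compound 1. As far as these compounds go, it is also open whether the same exchange would behave alike on compound 2, which differs from compound 1 in more than one place.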